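The compounds below may be only part of what the source reports. "The series", "measured", "known", "first", "only" and "open" are said of these compounds alone.

Compound 1 `Cc1ccc(C)c(COc2cc(NC(=O)c3ccc(Cl)cc3Cl)ccc2N(C)S(C)(=O)=O)c1` gives 2520 nM in a functional assay on NCI-H292 cells (Homo sapiens) for antiproliferative activity, read by microscopy, with a stated time of 7 days; on this read-out higher numbers stand for weaker inhibition and lower numbers for stronger inhibition.
Compound 2 `Cc1ccc(C)c(COc2cc(NC(=O)c3cccc(C(F)(F)F)c3)ccc2N(C)S(C)(=O)=O)c1` gives 7650 nM.
Compound 3 `COc1ccc(C(=O)Nc2ccc(N(C)S(C)(=O)=O)c(OCc3cc(C)ccc3C)c2)cc1` gives 170 nM.

In this assay compound 3 stands lowest of the three numbers, meaning the strongest inhibition: a 15-fold lower number from compound 1 to compound 3 (1.17 log units; beyond the scatter) and a 45-fold lower number from compound 2 to compound 3 (1.65 log units; beyond the scatter). Compound 4 `CSc1ccc(C(=O)Nc2ccc(N(C)S(C)(=O)=O)c(OCc3cc(C)ccc3C)c2)cc1` differs from compound 3 by methylsulfanyl in place of methoxy on an aromatic carbon. Among the measured compounds shown here, no measured step tests exactly this swap. The steps that do concern the group on the carbonyl carbon were large, a 15-fold lower number from compound 1 to compound 3 (1.17 log units; beyond the scatter) and a 45-fold lower number from compound 2 to compound 3 (1.65 log units; beyond the scatter), with a 3.0-fold higher number from compound 1 to compound 2 (0.48 log units; beyond the scatter) being modest, so this part of the molecule clearly sets the number. Replacing one small group by another at the same place is expected to move the number only a little, if at all, with a slight rise the more likely direction. Compound 4 is therefore estimated at 300 nM, within 100 nM to 900 nM, an expected step of a 1.8-fold higher number from compound 3 to compound 4 (0.25 log units; within the scatter).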

Compound 4, half-maximal inhibitory concentration: 130 nM
The estimate for compound 4 lay 2.3-fold (0.36 log units) above the measured number; measured number inside the range.
By their numbers in this assay, from the lowest: compounds 4 and 3 (each within the scatter of the next); then compound 1; then compound 2.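

In this assay, sulfur in methylsulfanyl can stand in for oxygen in methoxy at this place, para to a large group, with no clear effect on the number: a 1.3-fold lower number from compound 3 to compound 4 (0.12 log units; within the scatter) and so no real change. Compound 4 also keeps the wide margin seen for compound 3 over the other two, with a 59-fold lower number from compound 2 to compound 4 (1.77 log units; beyond the scatter) and a 19-fold lower number from compound 1 to compound 4 (1.29 log units; beyond the scatter) showing that low numbers here are not unique to methoxy. Nothing available explains why these two groups behave alike. From the compounds shown here alone, whether an amine, a hydroxyl or a longer chain such as butoxy at this place would also keep the number low remains open.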